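Working notes: hydrogen for chloro in compound 3

This account rests on a few compounds, and the source may have more. Where it says the series, first, only, none or still open, it means among the compounds named here.

Of the compounds shown here, three sharing one core have been tested in a functional assay on L1210 cells (Mus musculus) for antiproliferative activity, read by cell counting, with a stated time of 2 days (a lower number here means a stronger inhibitor, a higher number a weaker inhibitor), and none has yet given a number. Compound 1 `COc1cccc(C(=O)c2sc(N3CCCC3)nc2N)c1` is reported as > 200000 nM, which is a limit of the assay. Compound 2 `COc1ccccc1C(=O)c1sc(N2CCCC2)nc1N` is reported as > 200000 nM, which is also a limit. Compound 3 `Nc1nc(N2CCCC2)sc1C(=O)c1ccc(Cl)cc1` is reported as > 200000 nM, again only a limit and not a measured number. The whole set is summed up by the limit of > 200000 nM in this assay, at which 3 of the 3 values shown sit, so compound 3 has no rank within it.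

Compound 4 `Nc1nc(N2CCCC2)sc1C(=O)c1ccccc1` follows from compound 3 with one change: hydrogen in place of chloro on an aromatic carbon, para to a large group (hydrogen in place of chloro on an aromatic carbon). Among the measured compounds shown here, no step between measured compounds is available to gauge this change. In this assay, no shift beyond the usual scatter is expected in either direction, an expectation that rests only on the limit of compound 3 at > 200000 nM. The estimated change is a number no higher from compound 3 to compound 4 (the limit leaves the size open). A report as a limit is the likeliest outcome. For compound 4 the expected value is 200000 nM, with an estimated range from 80000 nM to 400000 nM.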

Compound 4, half-maximal inhibitory concentration: > 200000 nM
Compound 4: no number, only a limit (the forecaster's own chance of this, stated with the estimate: 80%); the middle value lies on the limit itself.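

No step from compound 1, compound 2 or compound 3 to compound 4 can be read, because every result in the set is a limit and not a number: the limit of > 200000 nM in this assay, at which 4 of the 4 values shown sit.

The compounds shown leave open whether any change to the shared core would give a measurable number in this assay, and how these aromatic substituents would rank.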